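Adding methyl groups to the benzyl group of compound 2

The source may report more compounds than this note shows. Statements on the series, on what has been measured and on what is new or still open speak of the compounds shown alone.

Values in a functional assay on DU-145 cells (Homo sapiens) for cytotoxicity, read by MTT assay; on this read-out higher numbers stand for weaker inhibition and lower numbers for stronger inhibition:
Compound 1 `COc1ccc2cc([C@H](C)c3nnc(SCc4ccc(Cl)cc4)n3-c3ccc(F)cc3)ccc2c1`: 57400 nM
Compound 2 `COc1ccc2cc([C@H](C)c3nnc(SCc4ccc(C)cc4)n3-c3ccc(F)cc3)ccc2c1`: 44300 nM
Compound 3 `COc1ccc2cc([C@H](C)c3nnc(SCc4ccc(C)cc4)n3-c3ccc(Cl)cc3)ccc2c1`: 18800 nM

Compound 2, at 44300 nM, sits within the scatter of compound 1, while compound 3 shows a lower number. Compound 4 `COc1ccc2cc([C@H](C)c3nnc(SCc4c(C)cc(C)cc4C)n3-c3ccc(F)cc3)ccc2c1` has not yet been measured in this assay. It departs from compound 2 by 2,4,6-trimethylphenyl in place of 4-methylphenyl on a saturated chain carbon bound to a sulfur.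

Two measured steps are available. The step of a 1.3-fold lower number from compound 1 to compound 2 (0.11 log units; within the scatter), methyl in place of chloro on an aromatic carbon, falls on the same group and is small. The step of a 2.4-fold lower number from compound 2 to compound 3 (0.37 log units; beyond the scatter), chloro in place of fluoro on an aromatic carbon, is modest but falls outside that group. For the measured compounds named here, no measured compound carries the 2,4,6-trimethylbenzyl group, so the guide is weak.

The expected change is an estimated 1.1-fold lower number from compound 2 to compound 4 (0.04 log units; within the scatter), with no clear direction expected. For compound 4 the estimated value is 40000 nM, with an expected range from 15000 nM to 100000 nM.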

Compound 4, half-maximal inhibitory concentration: 10200 nM
Compound 4: the middle estimate sits 3.9-fold (0.59 log units) above what was measured; measured number outside the range, below it.
By their numbers in this assay, from the lowest: compounds 4 and 3 (each within the scatter of the next); then compounds 2 and 1 (each within the scatter of the next).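

In this assay, the group on the saturated chain carbon bound to a sulfur can move the number beyond the scatter: a 4.3-fold lower number from compound 2 to compound 4 (0.64 log units; beyond the scatter) comes with 2,4,6-trimethylphenyl in place of 4-methylphenyl. The earlier change here, methyl in place of chloro, stayed within the scatter, whereas 2,4,6-trimethylphenyl also stands clear of 4-chlorophenyl, with a 5.6-fold lower number from compound 1 to compound 4 (0.75 log units; beyond the scatter) at this same place. Nothing among the data offers an explanation for this shift.

The compounds shown leave open whether all the methyl groups of the 2,4,6-trimethylphenyl group are needed for this lower number, or whether one methyl group added to 4-methylphenyl would suffice. They also leave open how an amine or a carboxylic acid on this phenyl ring would read in this assay in place of the methyl groups.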